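This account rests on a few compounds, and the source may have more. Where it says the series, first, only, none or still open, it means among the compounds named here.

Measured in a functional assay on CCRF-CEM cells (Homo sapiens) for cytotoxicity, in the absence of a further agent; a lower number here means a stronger inhibitor, a higher number a weaker inhibitor:
- Compound 1 `COC(=O)c1ccc(CN(CCCc2c(N)nc(N)nc2O)c2cc(F)cc(F)c2[N+](=O)[O-])cc1`: > 100000 nM, a limit
- Compound 2 `COC(=O)c1ccc(CN(CCCc2c(N)nc(N)nc2O)c2cc(F)c(F)cc2[N+](=O)[O-])cc1`: 66000 nM
- Compound 3 `Nc1nc(N)c(CCCN(Cc2ccc(NC(CCC(=O)O)C(=O)O)cc2)c2ccc([N+](=O)[O-])c(F)c2F)c(O)n1`: > 100000 nM, a limit

Compound 3 is known only through its limit, > 100000 nM. Much of the picture rests on (the limit of > 100000 nM in this assay, at which 2 of the 3 values shown sit). The change to compound 4 `COC(=O)c1ccc(CN(CCCc2c(N)nc(N)nc2O)c2ccc([N+](=O)[O-])c(F)c2F)cc1` is methoxycarbonyl in place of (1,3-dicarboxypropyl)amino on an aromatic carbon.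

Within the data shown here, no measured step covers this change. The only one, an at least 1.5-fold lower number from compound 1 to compound 2 (0.18 log units; that floor lies within the scatter), concerns the difluoro-nitrophenyl group and gives no size for the present swap. The closest guide is compound 2, which carries the same methoxycarbonyl and gives 66000 nM. Compound 1, with the same methoxycarbonyl, goes against any firm reading, since its result is a limit, > 100000 nM. A number near that of compound 2 is therefore expected, though another limit remains quite possible.

The expected change is an at least 1.4-fold lower number from compound 3 to compound 4 (0.15 log units; that floor lies within the scatter), towards a lower number and of uncertain size. For compound 4 the estimated value in this assay is 70000 nM, with an expected range from 20000 nM to 200000 nM.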

Compound 4, half-maximal inhibitory concentration: 55000 nM
Compound 4: middle estimate off by 1.3-fold (0.10 log units), on the high side; the measured number falls inside the stated range.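

In this assay, methoxycarbonyl in place of (1,3-dicarboxypropyl)amino on an aromatic carbon now has a measured step, an at least 1.8-fold lower number from compound 3 to compound 4 (0.25 log units; that floor lies within the scatter), but it is only a floor because compound 3 is known through a limit and the series often sits there: the limit of > 100000 nM in this assay, at which 2 of the 4 values shown sit.
With methoxycarbonyl held constant, the comparison of the two difluoro-nitrophenyl groups gives a 1.2-fold lower number from compound 2 to compound 4 (0.08 log units; within the scatter), so 2,3-difluoro-4-nitrophenyl and 4,5-difluoro-2-nitrophenyl are not told apart here.
The other comparison gives an at least 1.8-fold lower number from compound 1 to compound 4 (0.25 log units; that floor lies within the scatter), again only a floor, which does not separate 2,3-difluoro-4-nitrophenyl from 3,5-difluoro-2-nitrophenyl.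

Still open, from the compounds shown here alone, is whether a free carboxylic acid or an amide on that aromatic carbon would give a step beyond the scatter.
Also open, going by these compounds, is whether an amine in place of the nitro group, or a longer chain to the shared core, would shift the number at all.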